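The source may report more compounds than this note shows. Statements on the series, on what has been measured and on what is new or still open speak of the compounds shown alone.

Compound 3 `CC/C(=C(/c1ccc(/C=C/C(=O)O)cc1)c1cc2ccccc2[nH]1)c1ccc(OC)cc1` stands second highest of the three numbers recorded in a functional assay on MCF7 cells (Homo sapiens) for inhibition (a higher number here means a weaker inhibitor, a lower number a stronger inhibitor), where compound 3 gives 61 nM. Its nearest neighbour is compound 2 `CC/C(=C(/c1ccc(/C=C/C(=O)O)cc1)c1cc2ccccc2[nH]1)c1ccccc1OC(F)(F)F`, which in this assay gives 206 nM; the furthest is compound 1 `CC/C(=C(/c1ccc(/C=C/C(=O)O)cc1)c1cc2ccccc2[nH]1)c1ccccc1C#N`, which gives 9 nM. Compound 4 `CC/C(=C(/c1ccc(/C=C/C(=O)O)cc1)c1cc2ccccc2[nH]1)c1cccc(Cl)c1Cl` is not yet measured. The change from compound 3 to compound 4 is 2,3-dichlorophenyl in place of 4-methoxyphenyl on a double-bonded chain carbon bound to a double-bonded chain carbon and a saturated chain carbon. For the measured compounds named here, two measured steps touch this same place on the shared core: a 6.8-fold higher number from compound 1 to compound 3 (0.83 log units; beyond the scatter) and a 3.4-fold lower number from compound 2 to compound 3 (0.53 log units; beyond the scatter). Both are of modest size but in opposite directions, so this position tolerates variation without a single trend, and the third measured step, a 23-fold higher number from compound 1 to compound 2 (1.36 log units; beyond the scatter), shows that a change at the neighbouring ring can be large. Going by the values given here, no step in the set mirrors the entry of two chlorines, so the direction for compound 4 is uncertain; a step of modest size is expected, a 1.3-fold higher number from compound 3 to compound 4 (0.12 log units; within the scatter), with a wide range. Compound 4 is therefore estimated at 80 nM, between 20 nM and 400 nM.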

Compound 4, half-maximal inhibitory concentration: 898 nM
Estimate against measurement, compound 4: 11-fold (1.05 log units) below, outside the stated range (above it).
By their numbers in this assay, from the lowest: compound 1; then compound 3; then compound 2; then compound 4.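

In this assay, for the compounds shown here, compound 4 is the weakest inhibitor of the four, so this place on the shared core is more sensitive than the earlier compounds showed: the 2,3-dichlorophenyl group falls well behind the 4-methoxyphenyl group (a 15-fold higher number from compound 3 to compound 4 (1.17 log units; beyond the scatter)) and also behind the 2-(trifluoromethoxy)phenyl group (a 4.4-fold higher number from compound 2 to compound 4 (0.64 log units; beyond the scatter)), and the spread at this place now reaches its widest against the 2-cyanophenyl group (a 100-fold higher number from compound 1 to compound 4 (2.00 log units; beyond the scatter)). The heavy-atom count does not separate the groups that leave and enter, as the 4-methoxyphenyl and 2,3-dichlorophenyl groups have the same count. Nothing available explains this loss.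

On these data alone, whether the loss in compound 4 follows from one of its chlorines or needs both remains open. The compounds shown also leave open how a phenyl ring carrying an amine or a hydroxyl group would behave at this place.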